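The source may report more compounds than this note shows. Statements on the series, on what has been measured and on what is new or still open speak of the compounds shown alone.

Measured in an assay on microsomes from liver (strain Wistar) for inhibition of acyl-CoA desaturase 1 (Rattus norvegicus), read by HPLC, with stated times of 1 h and 60 min; a lower number here means a stronger inhibitor, a higher number a weaker inhibitor:
compound 1 `NC(=O)c1cnc(N2CCN(S(=O)(=O)c3ccccc3C(F)(F)F)CC2)s1` gives > 3000 nM
compound 2 `NC(=O)c1cnc(N2CCC(Sc3ccccc3C(F)(F)F)CC2)s1` gives 4 nM
compound 3 `NC(=O)c1cnc(N2CCC(Oc3ccccc3C(F)(F)F)CC2)s1` gives 3 nM

The number for compound 1 is a limit of this assay and not a measured value (the limit of > 3000 nM in this assay, at which 1 of the 3 values shown sits). Of the two numbers actually read, compound 3 with 3 nM and compound 2 with 4 nM sit within the usual scatter of each other, so neither can be set above the other; the pair only shows that the piperidine-linked ether and thioether both give low numbers in this assay.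

Compound 4 `NC(=O)c1nnc(N2CCC(Oc3ccccc3C(F)(F)F)CC2)s1` is not yet measured. It differs from compound 3 in one place: 5-carbamoyl-1,3,4-thiadiazol-2-yl in place of 5-carbamoyl-1,3-thiazol-2-yl on an amine nitrogen in a ring. Going by the values given here, no measured pair in this set carries the same change, so no step can be read off for it. The change keeps the carbamoyl group and the amine nitrogen attachment; what enters is one more ring nitrogen. The expectation is a step from compound 3 to compound 4 of a 1.7-fold higher number from compound 3 to compound 4 (0.22 log units; within the scatter), that is, none beyond the scatter or at most a small rise. Compound 4 is therefore estimated at 5 nM in this assay, with a range from 1.5 nM to 20 nM.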

Compound 4, half-maximal inhibitory concentration: 3 nM
Compound 4: the middle estimate sits 1.7-fold (0.22 log units) above what was measured, and the stated range covers the measured number.
By their numbers in this assay, from the lowest: compounds 3, 4 and 2 (each within the scatter of the next). At a limit, above all of these: compound 1.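

In this assay, 5-carbamoyl-1,3,4-thiadiazol-2-yl in place of 5-carbamoyl-1,3-thiazol-2-yl on the amine nitrogen in a ring gives no change at the digits printed from compound 3 to compound 4 (within the scatter). Compounds 1 to 3 all carry 5-carbamoyl-1,3-thiazol-2-yl and so say nothing about this place; this step shows that, with the ether of compound 3 held fixed, a carbon of this five-membered aromatic ring can give way to one more ring nitrogen without a step beyond the scatter. Nothing among the data shown bears on why the number holds.

Going by these compounds, whether the same exchange holds on the thioether of compound 2 stays open, as this single pair gives one reading of the change. Also open, on these data alone, is how much the carbamoyl group itself contributes, which a carboxylic acid or a nitrile in its place on either ring would address.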